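The source may hold more compounds than are shown below. What is called first, only, known or untested is meant among the compounds shown, and "the series" means these compounds.

Compound 1, `N[C@]1(C(=O)O)[C@H]2[C@@H](C[C@H]1OCc1ccccc1Cl)[C@]2(F)C(=O)O`, was tested in an assay on CHO cells for binding affinity to metabotropic glutamate receptor 2 (Rattus norvegicus) (on this read-out higher numbers stand for weaker inhibition and lower numbers for stronger inhibition), where compound 1 gives 4.99 nM. A second compound, compound 2, `N[C@]1(C(=O)O)[C@H]2[C@@H](C[C@H]1OCc1cccc3ccccc13)[C@]2(F)C(=O)O`, gives 5.36 nM in this assay. These two numbers lie within the usual scatter of each other, so compound 1 does not stand apart from compound 2 on the numbers available, and nothing can be said about which of the two binds more tightly. The next compound, compound 3, `N[C@]1(C(=O)O)[C@H]2[C@@H](C[C@H]1OCc1cccs1)[C@]2(F)C(=O)O`, has not yet been tested in this assay. It differs from compound 1 in one place: thiophen-2-yl in place of 2-chlorophenyl on a saturated chain carbon bound to an oxygen on a saturated carbon. For the measured compounds named here, no measured pair in this small set shows what such a swap of one aromatic ring for another does to the read-out, so any expectation rests on the structural change alone and carries wide uncertainty. A modest step toward a weaker number is expected, about the size of a 1.6-fold higher number from compound 1 to compound 3 (0.20 log units; within the scatter), which may well turn out to lie within the scatter. On that basis compound 3 is expected to give 8 nM in this assay, with a range from 3 nM to 25 nM.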

Compound 3, inhibition constant: 8.79 nM
Beside the measured number, compound 3's estimate is 1.1-fold (0.04 log units) below it; the measured number falls inside the stated range.
By their numbers in this assay, from the lowest: compounds 1, 2 and 3 (each within the scatter of the next).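

In this assay, putting thiophen-2-yl in place of 2-chlorophenyl gives a 1.8-fold higher number from compound 1 to compound 3 (0.25 log units; within the scatter) and so cannot be told apart from compound 1. For the compounds shown here, this is the first direct reading of a swap of one aromatic ring for another at this place, on a saturated chain carbon bound to an oxygen on a saturated carbon: a five-membered aromatic ring with 1 hetero atom and 5 heavy atoms replaces a six-membered aromatic ring of carbon only with 7 heavy atoms, and the read-out does not separate them. No measurement here bears on why the two groups read alike, so this stands as an observation without an explanation.

The compounds shown leave open whether the same holds beyond aromatic rings, as an amine or a carboxylic acid at this place could give a very different number. They also leave open what the chlorine of 2-chlorophenyl contributes by itself, a question that a plain phenyl group at this place would address directly.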